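Changing the Distal Aryl Group: Forecast for Compound 4

The source may report more compounds than this note shows. Statements on the series, on what has been measured and on what is new or still open speak of the compounds shown alone.

Compound 1 `COc1cccc(/C=C/C(=O)c2ccc(OC)c3c2OC(C)(C)C=C3)c1` — > 10000 nM
Compound 2 `COc1ccc(C(=O)/C=C/c2ccc([N+](=O)[O-])cc2)c2c1C=CC(C)(C)O2` — 3520 nM
Compound 3 `COc1ccc(/C=C/C(=O)c2ccc(OC)c3c2OC(C)(C)C=C3)cn1` — > 10000 nM

In a functional assay on SW-620 cells (Homo sapiens) for antiproliferative activity, read by MTT assay, with a stated time of 24 h (a higher number here means a weaker inhibitor, a lower number a stronger inhibitor), compound 1 gives only a limit of the assay, > 10000 nM. Compound 3 likewise sits at a limit, > 10000 nM. Compound 2 gives a number, 3520 nM. Two of the three values shown sit at the limit of > 10000 nM in this assay, at which 2 of the 3 values shown sit, so compound 1 is known only to lie at or beyond that limit.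

Compound 4 `COc1ccc(C(=O)/C=C/c2ccc(Cl)c(Cl)c2)c2c1C=CC(C)(C)O2` is not yet measured; it differs from compound 1 by 3,4-dichlorophenyl in place of 3-methoxyphenyl on a double-bonded chain carbon bound to a double-bonded chain carbon. The step that bears on this change is an at least 2.8-fold lower number from compound 1 to compound 2 (0.45 log units; beyond the scatter), made at the same place, whereas a step that the two limits leave unreadable from compound 1 to compound 3. For compound 4 a modest lowering is expected, an at least 2.5-fold lower number from compound 1 to compound 4 (0.39 log units; beyond the scatter). Compound 4 is therefore estimated at 4000 nM, with a range from 1500 nM to 10000 nM.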

Compound 4, half-maximal inhibitory concentration: 7700 nM
For compound 4 the middle estimate is 1.9-fold (0.28 log units) below the measured one; the range from low to high includes it.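

With 3,4-dichlorophenyl at this place, compound 4 gives a measured value in this assay, so 4-nitrophenyl is no longer the only group shown here to do so. Against the two methoxy-bearing groups the result is an at least 1.2-fold lower number from compound 1 to compound 4 (0.11 log units; that floor lies within the scatter) and an at least 1.2-fold lower number from compound 3 to compound 4 (0.11 log units; that floor lies within the scatter), and these steps are only floors, since compound 1 and compound 3 each stand at a limit of the assay, not at a number: the limit of > 10000 nM in this assay, at which 2 of the 4 values shown sit. The two measured groups also separate, with a 2.2-fold higher number from compound 2 to compound 4 (0.34 log units; beyond the scatter).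

From the compounds shown here alone, whether an aminomethyl group or a carboxylic acid on this ring would lower the number further remains open. So does the effect of a single chlorine.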